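Aryl urea series: sulfamoyl replaces trifluoromethyl

A few compounds are considered here, and "the series" means these few. Any claim that something is new, unique, unknown or untested is made for them only; others in the source may bear on it.

Compound 3 `N#CC1CN1C(=O)Nc1ccc(C(F)(F)F)cc1` gives 1500 nM in a functional assay on MCF7 cells (Homo sapiens) for inhibition (on this read-out higher numbers stand for weaker inhibition and lower numbers for stronger inhibition), the lowest of the three numbers recorded so far. Compound 1 `CCOC(=O)c1ccc(NC(=O)N2CC2C#N)cc1` gives 2300 nM and compound 2 `N#CC1CN1C(=O)Nc1ccccc1` gives 2900 nM; the steps of a 1.5-fold lower number from compound 1 to compound 3 (0.19 log units; within the scatter) and a 1.9-fold lower number from compound 2 to compound 3 (0.29 log units; within the scatter) both sit within the scatter, as does a 1.3-fold higher number from compound 1 to compound 2 (0.10 log units; within the scatter). Compound 4 `N#CC1CN1C(=O)Nc1ccc(S(N)(=O)=O)cc1` is not yet measured. It differs from compound 3 by sulfamoyl in place of trifluoromethyl on an aromatic carbon. Every measured step in the series exchanges the group on this same aromatic carbon, and none moved this assay beyond the scatter, so for a 1.3-fold higher number from compound 3 to compound 4 (0.12 log units; within the scatter) no step beyond the scatter is expected either. Compound 4 is therefore estimated at 2000 nM, with a range of 800 nM to 5000 nM.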

Compound 4, half-maximal inhibitory concentration: > 15000 nM
Compound 4 ended at the assay's limit; the forecaster's own chance of this, stated with the estimate: 5%; at least 7.5-fold (0.87 log units) between middle value and limit.
By their numbers in this assay, from the lowest: compounds 3, 1 and 2 (each within the scatter of the next). At a limit, above all of these: compound 4.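

Among the compounds shown here, at this aromatic carbon, hydrogen, ethoxycarbonyl and trifluoromethyl stay within the scatter of one another, whereas sulfamoyl gives the only steps beyond it in this assay: an at least 10-fold higher number from compound 3 to compound 4 (1.00 log units; beyond the scatter), an at least 5.1-fold higher number from compound 2 to compound 4 (0.71 log units; beyond the scatter) and an at least 6.5-fold higher number from compound 1 to compound 4 (0.81 log units; beyond the scatter). Compound 4 gives > 15000 nM, which is a limit of the assay. For the compounds shown here, the position is therefore not indifferent to the group it carries, as the earlier compounds suggested.

From the compounds shown here alone, whether the loss is specific to sulfamoyl remains open, as a methylsulfonyl group, a carboxylic acid or an amine at this carbon could show. The compounds shown give no cause for the loss.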